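Series notes: carboxy for hydroxy on the sulfanyl chain

The compounds below may be only part of what the source reports. "The series", "measured", "known", "first", "only" and "open" are said of these compounds alone.

Compound 1 `CC(=O)NCCNC[C@H]1O[C@@H](n2cc(C)c(=O)[nH]c2=O)C[C@@H]1O` gives 250000 nM in an assay on BHK21 (C13) cells (Mesocricetus auratus) for inhibition of thymidine kinase, cytosolic (Cricetulus griseus), using Lineweaver-Burk analysis; a higher number here means a weaker inhibitor, a lower number a stronger inhibitor. Compound 2 `Cc1cn([C@H]2C[C@H](O)[C@@H](CSCCO)O2)c(=O)[nH]c1=O` gives 800000 nM in this assay, the highest of the two numbers; the step of a 3.2-fold higher number from compound 1 to compound 2 (0.51 log units; beyond the scatter) is modest but beyond the scatter. Compound 3 `Cc1cn([C@H]2C[C@H](O)[C@@H](CSCCC(=O)O)O2)c(=O)[nH]c1=O` carries the change (carboxy in place of hydroxy on a saturated chain carbon, two bonds along the chain from a sulfur). For the measured compounds named here, no measured step touches this position: the only step, a 3.2-fold higher number from compound 1 to compound 2 (0.51 log units; beyond the scatter), concerns a different group on the chain and gives no guide to the new change. The expectation for compound 3 in this assay is therefore no shift beyond the scatter, a 1.1-fold lower number from compound 2 to compound 3 (0.06 log units; within the scatter). Compound 3 is estimated at 700000 nM, with a range of 200000 nM to 2500000 nM.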

Compound 3, inhibition constant: 500000 nM
For compound 3 the middle estimate is 1.4-fold (0.15 log units) above the measured one, and the stated range covers the measured number.
By their numbers in this assay, from the lowest: compounds 1, 3 and 2 (each within the scatter of the next, the first and the last beyond it).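

In this assay carboxy in place of hydroxy, on a saturated chain carbon two bonds along the chain from a sulfur, gives a 1.6-fold lower number from compound 2 to compound 3 (0.20 log units; within the scatter) and so does not separate the two compounds. For the compounds shown here, measured against compound 1, (2-carboxyethyl)sulfanyl in place of (2-acetamidoethyl)amino gives a 2.0-fold higher number from compound 1 to compound 3 (0.30 log units; within the scatter) while the hydroxy chain gave a 3.2-fold higher number from compound 1 to compound 2 (0.51 log units; beyond the scatter) as the only step of this pair beyond the scatter. No measured evidence bears on this result. Going by these compounds, whether an amine or a longer chain at this chain end would move the number beyond the scatter stays open.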